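Notes on an amide aryl swap and solubility

The compounds below may be only part of what the source reports. "The series", "measured", "known", "first", "only" and "open" are said of these compounds alone.

Compound 1 `CNc1nc(NCc2ccc(NC(=O)c3ccc(F)cc3)cc2)c2cc(C)ccc2n1` is the reference point of this small set. For the measured compounds named here, in a physicochemical assay for solubility, at pH 7.4 (on this read-out lower numbers stand for lower solubility and higher numbers for higher solubility), compound 1 gives 10 ug/mL, the highest of the three numbers so far. Compound 2 `CNc1nc(NCc2ccc(NC(=O)c3ccc(F)cc3)cc2)c2c(C)cccc2n1` has the same atoms as compound 1 joined differently; the difference between the two cores is not broken down here. In this assay compound 2 gives 2 ug/mL, a lower number than that of compound 1 by more than the usual scatter.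

Compound 3 `CNc1nc(NCc2ccc(NC(=O)c3ccc(Cl)nc3)cc2)c2c(C)cccc2n1` keeps the core of compound 2 and differs from it only at the amide: 6-chloropyridin-3-yl in place of 4-fluorophenyl on a carbonyl carbon. In this assay compound 3 gives 2 ug/mL. The step of no change at the digits printed from compound 2 to compound 3 (within the scatter) shows this exchange leaving the read-out essentially where it was.

Compound 4 `CNc1nc(NCc2ccc(NC(=O)c3ccc(Cl)nc3)cc2)c2cc(C)ccc2n1` is not yet measured. It carries the same change on the core of compound 1: 6-chloropyridin-3-yl in place of 4-fluorophenyl on a carbonyl carbon. The place is the same in both pairs, a carbonyl carbon whose other neighbour is an amide-type nitrogen, so the change in compound 1 to compound 4 is the same change as in compound 2 to compound 3. Going by the values given here, the step of no change at the digits printed from compound 1 to compound 4 (within the scatter) is expected to be small because no change at the digits printed from compound 2 to compound 3 (within the scatter) is the only precedent and it is flat. Compound 4 is therefore estimated at 10 ug/mL, with an expected range from 4 ug/mL to 25 ug/mL, resting on compound 1 at 10 ug/mL.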

Compound 4, solubility: 3 ug/mL
Estimate against measurement, compound 4: 3.3-fold (0.52 log units) above; the measured number lies below the stated range.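

In this assay, putting 6-chloropyridin-3-yl in place of 4-fluorophenyl on a carbonyl carbon gives a 3.3-fold lower number from compound 1 to compound 4 (0.52 log units; beyond the scatter), while the same change on the other core gives no change at the digits printed from compound 2 to compound 3 (within the scatter), so one step is beyond the usual scatter and the other within it. The change therefore does not carry over from one core to the other at a fixed size in this series, and the flat step alone was not a safe guide to the core of compound 1; with the new amide on both cores, compound 3 stands at 2 ug/mL and compound 4 at 3 ug/mL. Two matched pairs cannot show whether the core generally decides the size of this step, and nothing available here bears on why the two steps differ.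

The compounds shown leave open which part of the exchange goes with the step on the core of compound 1, the ring nitrogen or the chlorine in place of fluorine, a question that a 4-chlorophenyl amide or a 6-fluoropyridin-3-yl amide on both cores would address. They also leave open how the read-out on each core would respond to an amide aryl group carrying a morpholine or a carboxylic acid.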